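The compounds below may be only part of what the source reports. "The series", "measured", "known", "first", "only" and "open" are said of these compounds alone.

Measured in a functional assay (aorta) for inhibition, with Rattus norvegicus as the target; a lower number here means a stronger inhibitor, a higher number a weaker inhibitor:
Compound 1 `Cc1nsc(-c2ccc(N3CCN(c4cccc(C(F)(F)F)c4)CC3)cc2)n1`: 10 nM
Compound 2 `Cc1nsc(-c2ccc(N3CCN(c4cccc(C(F)(F)F)c4)CC3)nn2)n1`: 0.3 nM
Compound 3 `Cc1nsc(-c2ccc(N3CCN(c4cccc(F)c4)CC3)nn2)n1`: 6 nM

Compound 3, at 6 nM, lies within the usual scatter of compound 1 and well above compound 2. Compound 4 `Cc1nsc(-c2ccc(N3CCN(c4cccc([N+](=O)[O-])c4)CC3)nn2)n1` keeps the rest of compound 3 but carries nitro in place of fluoro on an aromatic carbon. For the measured compounds named here, only one measured step changes this same substituent: a 20-fold higher number from compound 2 to compound 3 (1.30 log units; beyond the scatter), which is large and beyond the scatter, with fluoro in place of trifluoromethyl. Going by the values given here, it shows that this assay can respond strongly to this substituent, but no nitro compound has yet been measured, so the direction rests on that single pair. A lower number is expected, though a smaller shift than that step. The expected step is a 3.0-fold lower number from compound 3 to compound 4 (0.48 log units; beyond the scatter). The estimated value for compound 4 is 2 nM, with an expected range from 0.4 nM to 10 nM.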

Compound 4, half-maximal inhibitory concentration: 3 nM
Beside the measured number, compound 4's estimate is 1.5-fold (0.18 log units) below it; the measured number falls inside the stated range.
By their numbers in this assay, from the lowest: compound 2; then compounds 4, 3 and 1 (each within the scatter of the next, the first and the last beyond it).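

In this assay, putting nitro in place of fluoro on the aromatic carbon gives a 2.0-fold lower number from compound 3 to compound 4 (0.30 log units; within the scatter), so the two groups are not separated here, although nitro enters with more heavy atoms and with hydrogen-bond acceptors that fluoro does not bring. Trifluoromethyl stays apart from nitro too, with a 10-fold higher number from compound 2 to compound 4 (1.00 log units; beyond the scatter), which matches a 20-fold higher number from compound 2 to compound 3 (1.30 log units; beyond the scatter). Among these three groups on the shared core, the response at this position therefore sets trifluoromethyl apart from the other two and does not grade all three.

On these data alone, whether an amine, a methoxy group or a nitrile here would fall with trifluoromethyl or with fluoro and nitro remains open, as does whether the same gap would appear on the core of compound 1. Nothing shown gives a reason for the separate standing of trifluoromethyl.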